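A few compounds are considered here, and "the series" means these few. Any claim that something is new, unique, unknown or untested is made for them only; others in the source may bear on it.

Working notes on the series. Compound 1 `CCCn1c(=O)n(C)c(=O)c2c1ncn2CC#N` gives 6600 nM in an assay on Cerebral cortex for binding affinity to adenosine receptor A1 (Cavia porcellus), read by radioligand binding; a lower number here means a stronger inhibitor, a higher number a weaker inhibitor. Compound 2 `CCCn1c(=O)n(C)c(=O)c2c1ncn2CCC#N` gives 88600 nM in this assay, the step being a 13-fold higher number from compound 1 to compound 2 (1.13 log units; beyond the scatter). Compound 3 `CCCn1c(=O)n(C)c(=O)c2c1ncn2CCN(C)C` gives > 200000 nM in this assay, which is a limit of the assay and not a number, and it sits at the limit of > 200000 nM in this assay, at which 1 of the 3 values shown sits. Among the values shown compound 3 is the weakest, with an at least 30-fold higher number from compound 1 to compound 3 (1.48 log units; beyond the scatter) and an at least 2.2-fold higher number from compound 2 to compound 3 (0.35 log units; beyond the scatter) both beyond the scatter. Compound 4 `CCCn1c(=O)n(C)c(=O)c2c1ncn2CCCN(C)C` carries (dimethylamino)methyl in place of dimethylamino on a saturated chain carbon, two bonds along the chain from an aromatic nitrogen. For the measured compounds named here, the nearest measured step of the same kind is a 13-fold higher number from compound 1 to compound 2 (1.13 log units; beyond the scatter), which made the number larger; no measured step speaks to lengthening a dimethylamino chain. Compound 4 is thus expected to remain at the limit, the expected step being a step that the limit leaves unreadable from compound 3 to compound 4. The estimate for compound 4 is 300000 nM, ranging from 100000 nM to 1000000 nM.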

Compound 4, inhibition constant: > 200000 nM
Compound 4 gave a limit, no number; the forecaster's own chance of this, stated with the estimate: 80%; the middle value does not contradict the limit.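

Compound 4 shows that lengthening the chain ending in dimethylamino brings no number back into this assay, and the step between the two limits cannot be read: the limit of > 200000 nM in this assay, at which 2 of the 4 values shown sit.

Both nitriles keep the lower numbers, with an at least 2.2-fold higher number from compound 2 to compound 4 (0.35 log units; beyond the scatter) and an at least 30-fold higher number from compound 1 to compound 4 (1.48 log units; beyond the scatter). Putting (dimethylamino)methyl in place of the nitrile raises the number on both chains: the same change on two cores in this assay, an at least 30-fold higher number (1.48 log units; beyond the scatter) from compound 1 to compound 3 and an at least 2.2-fold higher number (0.35 log units; beyond the scatter) from compound 2 to compound 4; the limit leaves it open whether they differ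

Going by these compounds, how far compound 3 and compound 4 lie past the limit stays open. Also open, on these data alone, is whether a primary amine or a carboxylic acid at the chain end would give a readable number.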